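Methoxy for methyl: an expected step in maximal response

The source may report more compounds than this note shows. Statements on the series, on what has been measured and on what is new or still open speak of the compounds shown alone.

Compound 1, `CC[C@H]1c2c(cc(F)c(F)c2O)[C@H](Nc2cccc3[nH]c(=O)ccc23)[C@@](O)(C(F)(F)F)C1OC`, gives 78% in a functional assay on THP-1 cells (Homo sapiens); a lower number here means a smaller maximal response, a higher number a larger maximal response.
Compound 2, `CCSC[C@@](O)([C@@H](Nc1cccc2nc(C)ccc12)c1ccc(C)cc1)C(F)(F)F`, gives 87% in this assay.

Compound 2 stands at the higher of the two numbers, but compound 1 lies within the scatter of it, so the two cannot be told apart. Compound 3, `CCSC[C@@](O)([C@@H](Nc1cccc2nc(C)ccc12)c1ccc(OC)cc1)C(F)(F)F`, has not yet been measured; it differs from compound 2 by methoxy in place of methyl on an aromatic carbon. Within the data shown here, no measured pair shows this change, so in this assay a small step is expected, in no clear direction and not beyond the scatter. Compound 3 is therefore estimated at 85%, in the range 70% to 100%, an expected step of a number 2 percentage points lower from compound 2 to compound 3 (within the scatter).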

Compound 3, largest response reached (Emax), in percent of the reference or control that the assay uses: 86%
Compound 3: the middle estimate sits 1 percentage points below what was measured; the measured number falls inside the stated range.
By their numbers in this assay, from the lowest: compounds 1, 3 and 2 (each within the scatter of the next).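

Methoxy in place of methyl gives a number 1 percentage points lower from compound 2 to compound 3 (within the scatter) in this assay and is the first change in one place that can be read in this series. On the aromatic carbon para to a large group, going from 4-methylphenyl to 4-methoxyphenyl adds one hydrogen-bond acceptor, yet the maximal response of compound 3 cannot be told apart from that of compound 2. Nothing at hand offers an explanation for this result. On these data alone, what remains open is whether an amine, a carboxylic acid or a longer chain such as ethoxy at this position would also leave the maximal response in place.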